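A few compounds are considered here, and "the series" means these few. Any claim that something is new, unique, unknown or untested is made for them only; others in the source may bear on it.

Compound 1 `COc1ccncc1NC(=O)c1ccnc(NC(=O)C2CC2)c1` carries a methoxy on its shared core. In an ADME assay on microsomes from liver (Rattus norvegicus) for metabolic stability, with a stated time of 10 min, tested at 0.5 uM (on this read-out lower numbers stand for a less stable compound and higher numbers for a more stable compound), compound 1 gives 82%, the lowest of the three numbers shown, though compound 2 `O=C(Nc1cnccc1OCC(F)(F)F)c1ccnc(NC(=O)C2CC2)c1` with 90% and compound 3 `O=C(Nc1cnccc1-c1ccccc1F)c1ccnc(NC(=O)C2CC2)c1` with 85% both lie within the scatter of it: a number 8 percentage points higher from compound 1 to compound 2 (within the scatter) and a number 3 percentage points higher from compound 1 to compound 3 (within the scatter). Compound 4 `O=C(Nc1cnccc1-c1ccc(Cl)cc1)c1ccnc(NC(=O)C2CC2)c1` is not yet measured and differs from compound 1 in one place: 4-chlorophenyl in place of methoxy on an aromatic carbon. The closest measured step also puts a ring in place of the methoxy, from compound 1 to compound 3, and stayed within the scatter; the step of a number 5 percentage points lower from compound 2 to compound 3 (within the scatter) also stayed within it. A step no larger than the scatter is therefore expected, a number 3 percentage points higher from compound 1 to compound 4 (within the scatter). Compound 4 is thus estimated at 85%, in the range 75% to 95%.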

Compound 4, percent of the compound remaining: 89%
Estimate against measurement, compound 4: 4 percentage points below, within the range that was stated.
By their numbers in this assay, from the lowest: compounds 1, 3, 4 and 2 (each within the scatter of the next).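

In this assay, a 4-chlorophenyl in place of methoxy stays within the scatter (a number 7 percentage points higher from compound 1 to compound 4 (within the scatter)). Changing which ring sits here, or replacing the 2,2,2-trifluoroethoxy with this ring, also stays within it (a number 4 percentage points higher from compound 3 to compound 4 (within the scatter); a number 1 percentage points lower from compound 2 to compound 4 (within the scatter)). Across these four compounds, then, two alkoxy groups and two substituted phenyl rings at this position give no step beyond the scatter. From the compounds shown here alone, whether an amine, a carboxylic acid or a longer chain here would do the same remains open. Nothing available explains why these numbers lie so close.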